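The source may hold more compounds than are shown below. What is called first, only, known or untested is meant among the compounds shown, and "the series" means these compounds.

In a functional assay on PC-3 cells (Homo sapiens) for inhibition, read by MTT assay, with a stated time of 72 h (a lower number here means a stronger inhibitor, a higher number a weaker inhibitor), compound 1 `O=C(CSc1nc(Nc2ccccc2)c2ccccc2n1)Nc1cccc(Cl)c1` gives 12600 nM. Compound 2 `C=CC(=O)Nc1cccc(NC(=O)CSc2nc(Nc3ccccc3Br)c3ccccc3n2)c1` gives 17100 nM in this assay, a number that sits within the scatter of the number for compound 1, so the two cannot be ranked. Compound 3 `C=CC(=O)Nc1cccc(NC(=O)CSc2nc(Nc3ccc(Br)cc3)c3ccccc3n2)c1` has not been measured; it carries 4-bromophenyl in place of 2-bromophenyl on a nitrogen on an aromatic ring and keeps the rest of compound 2 unchanged. Among the measured compounds shown here, no measured pair shows what such a move does, so the step from compound 2 is expected to stay within the scatter, with no direction favoured, as a 1.1-fold lower number from compound 2 to compound 3 (0.06 log units; within the scatter). Compound 3 is therefore estimated at 15000 nM, between 6000 nM and 40000 nM.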

Compound 3, half-maximal inhibitory concentration: 12400 nM
The estimate for compound 3 lay 1.2-fold (0.08 log units) above the measured number; low and high end bracket the measured number.
By their numbers in this assay, from the lowest: compounds 3, 1 and 2 (each within the scatter of the next).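

Among the compounds shown here, with 4-bromophenyl in place of 2-bromophenyl on the nitrogen, this assay gives the first direct reading at this position: a 1.4-fold lower number from compound 2 to compound 3 (0.14 log units; within the scatter), a step within the scatter. Compound 2 and compound 3 therefore cannot be ranked, and this pair shows no measurable preference between the two bromophenyl groups. Nothing available offers an explanation for this result. On these data alone, what remains open is whether an amine or a carboxylic acid in place of the bromine on this ring would give a step beyond the scatter.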